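Ethoxycarbonyl in place of 3-fluorophenyl on the shared core

This account rests on a few compounds, and the source may have more. Where it says the series, first, only, none or still open, it means among the compounds named here.

In an ADME assay on PANC-1 cells (Homo sapiens) for cytotoxicity, read by sulforhodamine B assay, with a stated time of 48 h, tested at 10 uM (a higher number here means more inhibition at the concentration tested (going by the name of the read-out), a lower number less inhibition), three compounds have been measured:
compound 1 `COc1nc2ccc(Br)cc2cc1C(c1ccccc1)n1cc(C2CC2)nn1` gives 21.8%
compound 2 `COc1nc2ccc(Br)cc2cc1C(c1ccccc1)n1cc(-c2cccc(F)c2)nn1` gives 15.5%
compound 3 `COc1nc2ccc(Br)cc2cc1C(c1ccccc1)n1cc(-c2ccccc2)nn1` gives 30.1%

Compound 2 holds the lowest of the three numbers; its nearest neighbour is compound 1, and a number 6.3 percentage points lower from compound 1 to compound 2 (within the scatter) is within the scatter, while a number 14.6 percentage points higher from compound 2 to compound 3 (beyond the scatter) lies beyond it. Compound 4 `CCOC(=O)c1cn(C(c2ccccc2)c2cc3cc(Br)ccc3nc2OC)nn1` differs from compound 2 at a single place: ethoxycarbonyl in place of 3-fluorophenyl on an aromatic carbon. All three measured steps alter the group on this same aromatic carbon: a number 6.3 percentage points lower from compound 1 to compound 2 (within the scatter) and a number 8.3 percentage points higher from compound 1 to compound 3 (within the scatter) stayed within the scatter, and only a number 14.6 percentage points higher from compound 2 to compound 3 (beyond the scatter) exceeded it, modestly. Among the compounds with values here, no measured compound carries an ethoxycarbonyl group, so the direction of this change cannot be read from a like-for-like step. Because compound 2 gives 15.5% and the other two compounds gave no lower number, an upward move is more likely than a downward one. For compound 4 a small upward step is expected, a number 6.5 percentage points higher from compound 2 to compound 4 (within the scatter), though a result within the scatter is just as plausible. Compound 4 is therefore estimated at 22%, with a range from 10% to 35%.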

Compound 4, a percentage reported as inhibition, at one concentration (the size of the read-out at that concentration, not a potency): 15.4%
The estimate for compound 4 lay 6.6 percentage points above the measured number, and the stated range covers the measured number.
By their numbers in this assay, from the lowest: compounds 4, 2, 1 and 3 (each within the scatter of the next, the first and the last beyond it).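

In this assay, a group with no ring and with hydrogen-bond acceptors on this aromatic carbon cannot be told apart from the 3-fluorophenyl group, a number 0.1 percentage points lower from compound 2 to compound 4 (within the scatter), or from the cyclopropyl group, a number 6.4 percentage points lower from compound 1 to compound 4 (within the scatter). Only the phenyl group stands apart from ethoxycarbonyl, a number 14.7 percentage points lower from compound 3 to compound 4 (beyond the scatter), so compound 3 now has modest steps beyond the scatter to both compound 2 and compound 4, while compound 1 remains within the scatter of all three others. Nothing available explains why these groups read as they do.

The compounds shown leave open whether a carboxylic acid, an amine or a longer chain on this carbon would move the number beyond the scatter of these four compounds. They also leave open whether the gap between phenyl and ethoxycarbonyl would persist on a core with other groups.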